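Ring size of the chain amine in the oxyquinoline series

A few compounds are considered here, and "the series" means these few. Any claim that something is new, unique, unknown or untested is made for them only; others in the source may bear on it.

Compound 1 `COc1cc2c(Oc3ccc(NC(=O)c4nn(-c5ccccc5)c(=O)cc4C)cc3F)ccnc2cc1OCCCN1CCCCC1`: 1370 nM
Compound 2 `COc1cc2c(Oc3ccc(NC(=O)c4nn(-c5ccccc5C)c(=O)cc4C)cc3F)ccnc2cc1OCCCN1CCCC1`: 2960 nM

In a functional assay on U-87MG ATCC cells (Homo sapiens) for inhibition, read by MTT assay, with a stated time of 72 h (on this read-out higher numbers stand for weaker inhibition and lower numbers for stronger inhibition), compound 2 gives the higher of the two numbers, and the gap to compound 1 is beyond the scatter; the two differ in more than one place, so no single step can be read from them. Compound 3 `COc1cc2c(Oc3ccc(NC(=O)c4nn(-c5ccccc5C)c(=O)cc4C)cc3F)ccnc2cc1OCCCN1CCCCC1` is compound 2 with piperidin-1-yl in place of pyrrolidin-1-yl on a saturated chain carbon, three bonds along the chain from an oxygen on an aromatic ring. Among the measured compounds shown here, no measured pair isolates this change. The step of a 1.4-fold lower number from compound 2 to compound 3 (0.15 log units; within the scatter) is expected to be small, at most slightly toward a lower number, and may not exceed the scatter. Compound 3 is estimated at 2100 nM, with a range of 900 nM to 4800 nM.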

Compound 3, half-maximal inhibitory concentration: 2500 nM
Beside the measured number, compound 3's estimate is 1.2-fold (0.08 log units) below it; measured number inside the range.
By their numbers in this assay, from the lowest: compounds 1, 3 and 2 (each within the scatter of the next, the first and the last beyond it).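

Piperidin-1-yl in place of pyrrolidin-1-yl on a saturated chain carbon is now isolated in this assay as a 1.2-fold lower number from compound 2 to compound 3 (0.07 log units; within the scatter) and the effect of ring size at this position cannot be separated from the scatter. Compound 3 also isolates methyl in place of hydrogen on an aromatic carbon as a 1.8-fold higher number from compound 1 to compound 3 (0.26 log units; within the scatter) and this step likewise cannot be separated from the scatter. No available evidence bears on these results.

On these data alone, whether a morpholine at the chain end or a longer chain would give a step beyond the scatter remains open. Also open, as far as these compounds go, is whether the methyl step holds with pyrrolidin-1-yl on the chain.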